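A few compounds are considered here, and "the series" means these few. Any claim that something is new, unique, unknown or untested is made for them only; others in the source may bear on it.

In an ADME assay on microsomes from liver (Homo sapiens) for metabolic stability, read by LC-MS, using NADPH, tested at 1 uM (on this read-out higher numbers stand for a longer-lived compound and lower numbers for a shorter-lived compound), compound 1 `N#Cc1cnc(NC(=O)CCCOc2ccccc2)s1` gives 0.15 h and compound 2 `Cc1cnc(NC(=O)CCCOc2cccc(Cl)n2)s1` gives 0.117 h, while compound 3 `N#Cc1cnc(NC(=O)CCCOc2cccc(C(F)(F)F)c2)s1` gives 1.33 h as the highest of the three numbers, beyond the scatter from both others. Compound 4 `N#Cc1cnc(NC(=O)CCCOc2cccc(Cl)c2)s1` is not yet measured and differs from compound 3 by chloro in place of trifluoromethyl on an aromatic carbon in one place, chloro in place of trifluoromethyl on an aromatic carbon.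

Among the compounds with values here, one measured step bears directly on this change: an 8.9-fold higher number from compound 1 to compound 3 (0.95 log units; beyond the scatter) for trifluoromethyl in place of hydrogen on an aromatic carbon, a step beyond the scatter. Within the data shown here, compound 2 differs from the others in more than one place and offers no clean step. Among the measured compounds shown here, no measured compound carries chloro on a six-membered aromatic ring of carbon only, so the size of the change remains uncertain.

The working expectation is that chloro keeps part of the gain seen with trifluoromethyl. The expected step is a 2.2-fold lower number from compound 3 to compound 4 (0.35 log units; beyond the scatter) towards a lower number in this assay, smaller than the measured gain. Compound 4 is estimated at 0.6 h, with an expected range from 0.25 h to 1.3 h for the half-life.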

Compound 4, half-life in the Homo sapiens assay: 0.25 h
Estimate against measurement, compound 4: 2.4-fold (0.38 log units) above; measured number inside the range.
By their numbers in the Homo sapiens assay, from the lowest: compounds 2, 1 and 4 (each within the scatter of the next, the first and the last beyond it); then compound 3.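

In the Homo sapiens assay chloro at this place does not hold what trifluoromethyl gives: the record shows a 5.3-fold lower number from compound 3 to compound 4 (0.73 log units; beyond the scatter) and, against hydrogen, a 1.7-fold higher number from compound 1 to compound 4 (0.22 log units; within the scatter). Of the two groups tried on this aromatic carbon, only trifluoromethyl therefore separates from hydrogen beyond the scatter, so a substituent here does not by itself lengthen the half-life. In a physicochemical assay for solubility, read by nephelometry, at pH 2 (on this read-out lower numbers stand for lower solubility and higher numbers for higher solubility), compound 3 gives < 1600 nM, which is a limit of the assay. In the physicochemical assay compound 4 gives < 1600 nM, which is also a limit of the assay. In the physicochemical assay the step between these two compounds cannot be read, as both values are limits of the assay: the limit of < 1600 nM in the physicochemical assay, at which 2 of the 2 values shown sit.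

Still open, going by these compounds, is whether methoxy, an amine or a carboxylic acid in this place would behave like trifluoromethyl or like chloro. The compounds shown also leave open how a longer chain between the amide and the ether oxygen would change the half-life.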